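Swapping the Para Group on the Benzoate Ring

This account rests on a few compounds, and the source may have more. Where it says the series, first, only, none or still open, it means among the compounds named here.

Two measured compounds share one core. Compound 1 `O=C(OC1(C(=O)Nc2ccc([N+](=O)[O-])cc2)CCCCC1)c1ccc(C(F)(F)F)cc1` gives 26 nM in a functional assay on NFS-60 cells (Mus musculus) for inhibition, read by MTT assay, with a stated time of 72 h; on this read-out higher numbers stand for weaker inhibition and lower numbers for stronger inhibition. Compound 2 `COc1ccc(C(=O)OC2(C(=O)Nc3ccc([N+](=O)[O-])cc3)CCCCC2)cc1` gives 38.8 nM in this assay; it stands nearest to compound 1, and the step of a 1.5-fold higher number from compound 1 to compound 2 (0.17 log units; within the scatter) is within the scatter, so the two cannot be told apart. Compound 3 `O=C(OC1(C(=O)Nc2ccc([N+](=O)[O-])cc2)CCCCC1)c1ccc([N+](=O)[O-])cc1` differs from compound 2 in one place: nitro in place of methoxy on an aromatic carbon. For the measured compounds named here, the only measured step at this position, a 1.5-fold higher number from compound 1 to compound 2 (0.17 log units; within the scatter), did not move the number beyond the scatter, so no step beyond the scatter is expected here either. Compound 3 is estimated at 30 nM, within 12 nM to 80 nM, an expected step of a 1.3-fold lower number from compound 2 to compound 3 (0.11 log units; within the scatter).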

Compound 3, half-maximal inhibitory concentration: 7.7 nM
Beside the measured number, compound 3's estimate is 3.9-fold (0.59 log units) above it; measured number below the stated range.
By their numbers in this assay, from the lowest: compound 3; then compounds 1 and 2 (each within the scatter of the next).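

The group at this position can move the number after all, which the pair of compound 1 and compound 2 did not show. In this assay nitro in place of methoxy gives a 5.0-fold lower number from compound 2 to compound 3 (0.70 log units; beyond the scatter) and nitro in place of trifluoromethyl gives a 3.4-fold lower number from compound 1 to compound 3 (0.53 log units; beyond the scatter) and both steps lie beyond the scatter. Nothing measured here explains why nitro differs from the other two groups. Open, going by these compounds, is how an amine, a carboxylic acid or a nitrile would fare at this position, and whether nitro would give a similar step at another place on this ring.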